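Replacing 2-Ethylphenyl with 3-Hydroxyphenyl on the Shared Core

The compounds below may be only part of what the source reports. "The series", "measured", "known", "first", "only" and "open" are said of these compounds alone.

Measured compounds:
compound 1, `COC(=O)C1=C(C)N=C(C)/C(=C(\O)OC)C1c1ccccc1I`, 46.8 nM
compound 2, `COC(=O)C1=C(C)N=C(C)/C(=C(\O)OC)C1c1cccc(N)c1`, 2000 nM
compound 3, `CCc1ccccc1C1C(C(=O)OC)=C(C)N=C(C)/C1=C(\O)OC`, 6.46 nM

All three compounds were tested in a functional assay (muscle tissue) with Cavia porcellus as the target; a lower number here means that less compound is needed, a higher number that more compound is needed for the effect. Compound 3 gives the lowest of the three numbers, with 6.46 nM; its nearest neighbour is compound 1, and compound 2 is furthest from it. Compound 4, `COC(=O)C1=C(C)N=C(C)/C(=C(\O)OC)C1c1cccc(O)c1`, has not yet been measured. It differs from compound 3 in one place: 3-hydroxyphenyl in place of 2-ethylphenyl on a saturated ring carbon.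

For the measured compounds named here, two measured steps bear on this change. The step of a 310-fold lower number from compound 2 to compound 3 (2.49 log units; beyond the scatter) describes the reverse direction, from an aryl group carrying an amino substituent in the 3-position to 2-ethylphenyl, and it was large. The step of a 43-fold higher number from compound 1 to compound 2 (1.63 log units; beyond the scatter), from 2-iodophenyl to 3-aminophenyl, was also large and in the direction of a higher number. Going by the values given here, no measured compound carries a 3-hydroxyphenyl group, so how closely it would track 3-aminophenyl is not known from these data. A large step toward a higher number is therefore expected, a 150-fold higher number from compound 3 to compound 4 (2.19 log units; beyond the scatter), placing compound 4 near compound 2. The estimate for compound 4 is 1000 nM, with a range from 200 nM to 5000 nM.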

Compound 4, half-maximal effective concentration: 1000 nM
Compound 4: the middle estimate sits on the measured number at the digits printed; the range from low to high includes it.
By their numbers in this assay, from the lowest: compound 3; then compound 1; then compounds 4 and 2 (each within the scatter of the next).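

In this assay, 3-hydroxyphenyl in place of 2-ethylphenyl gives a 150-fold higher number from compound 3 to compound 4 (2.19 log units; beyond the scatter) and, in place of 2-iodophenyl, a 21-fold higher number from compound 1 to compound 4 (1.33 log units; beyond the scatter); at this saturated ring carbon, a second group now sits far from 2-ethylphenyl and 2-iodophenyl in its number. Hydroxy in place of amino on the aromatic carbon gives a 2.0-fold lower number from compound 2 to compound 4 (0.30 log units; within the scatter), so 3-hydroxyphenyl and 3-aminophenyl cannot be told apart here. The high number of compound 2 is therefore not unique to the amino group, as the hydroxy group of compound 4 lies within the scatter of it.

On these data alone, whether these high numbers go with where the substituent sits on the phenyl ring or with the amino and hydroxy groups themselves stays open, and a 3-ethylphenyl or a 2-hydroxyphenyl group would separate the two. Nothing at hand gives a measured reason for the size of these steps.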